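Hydroxyalkyl chains replacing the methyl ester

A few compounds are considered here, and "the series" means these few. Any claim that something is new, unique, unknown or untested is made for them only; others in the source may bear on it.

Going by the values given here, compound 1 `COC(=O)C(Cc1cccc(OCC(=O)O)c1)c1nc(-c2ccccc2)c(-c2ccccc2)o1` gives 80 nM in a functional assay for inhibition, with Homo sapiens as the target (a lower number here means a stronger inhibitor, a higher number a weaker inhibitor), the lowest of the two numbers measured so far. Compound 2 `O=C(O)COc1cccc(CC(CCO)c2nc(-c3ccccc3)c(-c3ccccc3)o2)c1` gives 2920 nM in this assay; the step of a 37-fold higher number from compound 1 to compound 2 (1.56 log units; beyond the scatter) bears directly on the change studied here. Compound 3 `O=C(O)COc1cccc(CC(CCCCO)c2nc(-c3ccccc3)c(-c3ccccc3)o2)c1` differs from compound 1 by 4-hydroxybutyl in place of methoxycarbonyl on a saturated chain carbon bound to an aromatic carbon and a saturated chain carbon, a longer hydroxyalkyl chain in the same place. Among the compounds with values here, because the only relevant step a 37-fold higher number from compound 1 to compound 2 (1.56 log units; beyond the scatter) was large and upward, compound 3 is expected to show a similar loss, about a 25-fold higher number from compound 1 to compound 3 (1.40 log units; beyond the scatter). The estimate for compound 3 in this assay is 2000 nM, within 500 nM to 8000 nM.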

Compound 3, half-maximal inhibitory concentration: 4680 nM
Compound 3: middle estimate off by 2.3-fold (0.37 log units), on the low side, within the range that was stated.
By their numbers in this assay, from the lowest: compound 1; then compounds 2 and 3 (each within the scatter of the next).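

In this assay, 4-hydroxybutyl in place of methoxycarbonyl on this saturated chain carbon gives a 59-fold higher number from compound 1 to compound 3 (1.77 log units; beyond the scatter), so the large loss is not confined to 2-hydroxyethyl. Between the two hydroxyalkyl chains the step is a 1.6-fold higher number from compound 2 to compound 3 (0.20 log units; within the scatter), so these two chains cannot be told apart here and neither comes near compound 1. No supporting data bear on the reason for this loss.

From the compounds shown here alone, whether an ethyl ester, a carboxylic acid or a primary amide on this carbon would stay close to compound 1 remains open. So does the outcome for hydroxymethyl, a shorter hydroxyalkyl chain.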